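The source may report more compounds than this note shows. Statements on the series, on what has been measured and on what is new or still open speak of the compounds shown alone.

Working notes on the series

Three compounds of the shared core have been run in a functional assay on the whole organism (strain Wistar) for inhibition, with Rattus norvegicus as the target, read by paw edema, with stated times of 30 min and 3 h, at a dose of 0.05 mmol/kg by the oral route; a lower number here means less inhibition, a higher number more inhibition at the dose given (going by the name of the read-out). Compound 1 `CS(=O)(=O)c1ccc(N2N=C(c3ccc(Br)cc3)CCC2=O)cc1` gives 10%. Compound 2 `CS(=O)(=O)c1ccc(N2N=C(c3ccc(Cl)c(Cl)c3)CCC2=O)cc1` gives 26.6%, and the step of a number 16.6 percentage points higher from compound 1 to compound 2 (beyond the scatter) rests on the 3,4-dichlorophenyl in place of 4-bromophenyl. Compound 3 `Cc1ccc(O)c(C2=NN(c3ccc(S(C)(=O)=O)cc3)C(=O)CC2)c1` gives 66.6%, the highest of the three numbers, standing above compound 2 by the step of a number 40 percentage points higher from compound 2 to compound 3 (beyond the scatter) and above compound 1 by the step of a number 56.6 percentage points higher from compound 1 to compound 3 (beyond the scatter), both beyond the scatter.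

Compound 4 `CS(=O)(=O)c1ccc(N2N=C(c3ccc(F)cc3)CCC2=O)cc1` is not yet measured. Against compound 3 the change is 4-fluorophenyl in place of 2-hydroxy-5-methylphenyl on a carbon with a double bond to nitrogen. Among the compounds with values here, the steps that bear on it are those that carry the 2-hydroxy-5-methylphenyl away or in: the step of a number 56.6 percentage points higher from compound 1 to compound 3 (beyond the scatter) and the step of a number 40 percentage points higher from compound 2 to compound 3 (beyond the scatter). Compound 4 carries 4-fluorophenyl at the place where compound 1 carries 4-bromophenyl and compound 2 carries 3,4-dichlorophenyl, so it is expected to fall back toward those two, that is a large step downward in this assay, expected as a number 51.6 percentage points lower from compound 3 to compound 4 (beyond the scatter).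

Compound 4 is therefore expected to give about 15% in this assay, within a range from 0% to 40%, because compound 1 with a related group at the same place gave 10% and compound 2 gave 26.6%.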

Compound 4, a percentage reported as inhibition, in the whole organism at one dose (the size of the read-out at that dose, not a potency): 60%
Compound 4: middle estimate off by 45 percentage points, on the low side; measured number outside the range, above it.
By their numbers in this assay, from the lowest: compound 1; then compound 2; then compounds 4 and 3 (each within the scatter of the next).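

In this assay, the step of a number 6.6 percentage points lower from compound 3 to compound 4 (within the scatter) shows that a high number at this position does not depend on the 2-hydroxy-5-methylphenyl or its hydrogen-bond donor, as the 4-fluorophenyl has no such donor. The halogen-bearing groups also do not behave as one low class: the step of a number 50 percentage points higher from compound 1 to compound 4 (beyond the scatter) comes with fluoro in place of bromo on an aromatic carbon, and the step of a number 33.4 percentage points higher from compound 2 to compound 4 (beyond the scatter) comes with 4-fluorophenyl in place of 3,4-dichlorophenyl, so the outcome at this position varies strongly among these groups, with compound 1 and compound 2 going against any reading of halogen substitution as uniformly poor. No available data explain these differences in the read-out.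

Among the compounds shown, the hydroxy and methyl groups occur only together, which leaves open what each contributes alone, and a lone 4-chloro group would be needed to show whether the large gap between fluoro and bromo is graded across the halogens. How an amine or a methoxy group at the same place of the phenyl ring would read also remains open, as does how any of these compounds would compare across doses.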